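A few compounds are considered here, and "the series" means these few. Any claim that something is new, unique, unknown or untested is made for them only; others in the source may bear on it.

In a functional assay, with a stated time of 10 min (a higher number here means a weaker inhibitor, a lower number a stronger inhibitor), compound 3 (`CCCCCCCCCCCCOc1cc(OC)ccc1C(C)=O`) gives 65600000 nM and compound 2 (`CCCCCCCCCCOc1cc(OC)ccc1C(C)=O`) gives 57400000 nM. For the measured compounds named here, these two lie within the scatter of each other and together form the high end of the numbers so far, far from compound 1 (`CCCCCCCCCCCCCCCCOc1cc(OC)c(Br)cc1C(C)=O`) at 100000 nM.

Compound 4 (`CCCCCCCCCCCCCCCCOc1cc(OC)ccc1C(C)=O`) lengthens the chain of compound 3: butyl in place of hydrogen on a saturated chain carbon, ten or more bonds along the chain from an oxygen on an aromatic ring. The change sits on a saturated chain carbon.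

Going by the values given here, only one measured step is of the same kind: a 1.1-fold higher number from compound 2 to compound 3 (0.06 log units; within the scatter). That step gives no sign that chain length moves the number. Compound 1 carries the same chain as compound 4 but also a bromine on the core, which compound 4 lacks. With only these compounds, the low number of compound 1 at 100000 nM cannot be divided between chain and bromine. It therefore supports only a cautious lean towards a lower number, and most of the gap is not carried over.

The expected change is modest and downward, close to the edge of the scatter: a 2.2-fold lower number from compound 3 to compound 4 (0.34 log units; beyond the scatter). For compound 4 the estimated value is 30000000 nM, with an expected range from 1500000 nM to 100000000 nM.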

Compound 4, half-maximal inhibitory concentration: 61500000 nM
The estimate for compound 4 lay 2.1-fold (0.31 log units) below the measured number, and the stated range covers the measured number.
By their numbers in this assay, from the lowest: compound 1; then compounds 2, 4 and 3 (each within the scatter of the next).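

In this assay, the longer chains bring no visible shift on the core without bromine: butyl in place of hydrogen gives a 1.1-fold lower number from compound 3 to compound 4 (0.03 log units; within the scatter) and stays level with the earlier pair, while hexyl in place of hydrogen gives a 1.1-fold higher number from compound 2 to compound 4 (0.03 log units; within the scatter) across the full chain series, so compound 2, compound 3 and compound 4 show no dependence on chain length at this position. With the chain held constant, hydrogen in place of bromo on an aromatic carbon gives a 620-fold higher number from compound 1 to compound 4 (2.79 log units; beyond the scatter) and is a large step, so the low number of compound 1 can now be tied to the bromo group in this pair rather than to the chain. No measured evidence offers an explanation for either result.

On these data alone, whether the bromo step keeps its size with the shorter chains of compound 2 and compound 3 remains open, as does whether chain length matters once the bromo group is present. Also open, as far as these compounds go, is how another group on that aromatic carbon, such as chloro, nitrile or an amine, would compare with bromo, and whether a chain carrying a carboxylic acid at its end would move the number at all.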